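Chloro in Place of Bromo: Estimating Compound 4

The source may report more compounds than this note shows. Statements on the series, on what has been measured and on what is new or still open speak of the compounds shown alone.

Compound 2 `Cc1ccc(CS/C(=C/c2ccc(Br)cc2)C(=O)c2ccc(Cl)cc2)cc1` was tested in a functional assay on DU-145 cells (Homo sapiens) for inhibition, read by trypan blue exclusion, with a stated time of 96 h (a higher number here means a weaker inhibitor of growth, a lower number a stronger inhibitor of growth), where compound 2 gives 10000 nM. Among the three measured compounds this places compound 2 second highest: compound 3 `O=C(/C(=C\c1ccc(Br)cc1)SCc1ccc(F)cc1)c1ccc(Cl)cc1` gives 9000 nM, a step of a 1.1-fold lower number from compound 2 to compound 3 (0.05 log units; within the scatter), while compound 1 `CSc1ccc(/C=C(/SCc2ccc(C)cc2)C(=O)c2ccc(Cl)cc2)cc1` gives 25000 nM, a step of a 2.5-fold lower number from compound 1 to compound 2 (0.40 log units; beyond the scatter). Compound 4 `Cc1ccc(CS/C(=C/c2ccc(Cl)cc2)C(=O)c2ccc(Cl)cc2)cc1` is not yet measured and differs from compound 2 by chloro in place of bromo on an aromatic carbon. Among the compounds with values here, the only measured step at this same carbon, a 2.5-fold lower number from compound 1 to compound 2 (0.40 log units; beyond the scatter), was modest, and the other step, a 1.1-fold lower number from compound 2 to compound 3 (0.05 log units; within the scatter), lies on a different ring and stayed within the scatter. Nothing here points to a move beyond the scatter, so the expected step is no change at the digits printed from compound 2 to compound 4 (within the scatter). Compound 4 is therefore estimated at 10000 nM, within 5000 nM to 20000 nM.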

Compound 4, concentration for 50% growth inhibition: 10000 nM
For compound 4 middle estimate and measured number coincide at the digits printed, within the range that was stated.
By their numbers in this assay, from the lowest: compounds 3, 2 and 4 (each within the scatter of the next); then compound 1.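

At this aromatic carbon, chloro and bromo cannot be told apart in this assay, with no change at the digits printed from compound 2 to compound 4 (within the scatter). Chloro also gives the same modest gain over methylsulfanyl as bromo did, with a 2.5-fold lower number from compound 1 to compound 4 (0.40 log units; beyond the scatter), so two halogens now stand on the same side of that step. No measurement is available here that bears on the reason for this. Still open, as far as these compounds go, is whether an amine or a carboxylic acid on this carbon would stay close to the two halogen compounds or fall nearer to compound 1.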